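The compounds below may be only part of what the source reports. "The series", "measured", "known", "first", "only" and "open" are said of these compounds alone.

The study concerns four close relatives built on one shared core, each assessed in a functional assay on P388 cells (Mus musculus) for cytotoxicity, read by MTT assay, with a stated time of 48 h; a higher number here means a weaker inhibitor, a lower number a stronger inhibitor. Compound 1 `C=C/C=C\[C@H](C)[C@H](OC(N)=O)[C@@H](C)[C@H](OC(C)=O)[C@@H](C)C/C(C)=C\[C@H](C)[C@@H](O)[C@@H](C)/C=C\[C@H](C[C@@H]1OC(=O)[C@H](C)[C@@H](OC(C)=O)[C@H]1C)OC(C)=O` gives in this assay only a limit, > 6920 nM. Compound 2 `C=C/C=C\[C@H](C)[C@H](OC(N)=O)[C@@H](C)[C@H](O)[C@@H](C)C/C(C)=C\[C@H](C)[C@@H](OC(C)=O)[C@@H](C)/C=C\[C@H](C[C@@H]1OC(=O)[C@H](C)[C@@H](OC(C)=O)[C@H]1C)OC(C)=O` has the same atoms as compound 1 joined differently; the difference between the two cores is not broken down here. In this assay compound 2 gives 166 nM. Compound 3 `C=C/C=C\[C@H](C)[C@H](OC(N)=O)[C@@H](C)[C@H](O)[C@@H](C)C/C(C)=C\[C@H](C)[C@@H](OC(C)=O)[C@@H](C)/C=C\[C@@H](O)C[C@@H]1OC(=O)[C@H](C)[C@@H](OC(C)=O)[C@H]1C` is derived from compound 2 by the change (hydrogen in place of acetyl on an oxygen on a saturated carbon). In this assay compound 3 gives 103 nM, and the step of a 1.6-fold lower number from compound 2 to compound 3 (0.21 log units; within the scatter) lies within the scatter, so the two values are treated as alike.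

The unmeasured compound 4 `C=C/C=C\[C@H](C)[C@H](OC(N)=O)[C@@H](C)[C@H](OC(C)=O)[C@@H](C)C/C(C)=C\[C@H](C)[C@@H](O)[C@@H](C)/C=C\[C@@H](O)C[C@@H]1OC(=O)[C@H](C)[C@@H](OC(C)=O)[C@H]1C` stands to compound 1 as compound 3 stands to compound 2. The change is hydrogen in place of acetyl on an oxygen on a saturated carbon, and its place reads word for word as for the change from compound 2 to compound 3, so it is the same change, made on a different core; among the compounds shown it occurs twice. For compound 4 the expected step that the limit leaves unreadable from compound 1 to compound 4 is taken to be small, resting on the measured step of a 1.6-fold lower number from compound 2 to compound 3 (0.21 log units; within the scatter), which stayed within the scatter.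

Compound 1 sits at the limit (the limit of > 6920 nM in this assay, at which 1 of the 3 values shown sits). Compound 4 is therefore expected at 10000 nM, within a range from 3500 nM to 40000 nM, and it is likely that this assay will again report only a limit for it.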

Compound 4, half-maximal inhibitory concentration: 1150 nM
Compound 4: middle estimate off by 8.7-fold (0.94 log units), on the high side; the measured number lies below the stated range.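

In this assay, the change from acetoxy to hydroxy, on an oxygen on a saturated carbon, gives an at least 6.0-fold lower number from compound 1 to compound 4 (0.77 log units; beyond the scatter), so this step clearly exceeds the usual scatter, whereas the same change on the other core stays within it. The change therefore does not carry over with the same size from one core to the other in this series, and the step measured on one core would not have predicted the step on the other: the same change on two cores in this assay, a 1.6-fold lower number (0.21 log units; within the scatter) from compound 2 to compound 3 and an at least 6.0-fold lower number (0.77 log units; beyond the scatter) from compound 1 to compound 4, at least 3.7-fold (0.57 log units) apart, beyond the scatter of two such steps. The result does not give the full size of the step on the core of compound 1, only a lower bound, and with just two cores shown it says nothing about why they differ or how the change would behave on a third: the limit of > 6920 nM in this assay, at which 1 of the 4 values shown sits.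

The compounds shown leave open whether a methyl ether or a longer acyl chain such as butyryl, in place of the acetyl on an oxygen on a saturated carbon, would follow the hydroxy compounds on either core. They also leave open whether a carbamate or an amine at that place would keep the gap between the two cores.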